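Series notes: amide N-methylation on the benzyl carboxamide arm

A few compounds are considered here, and "the series" means these few. Any claim that something is new, unique, unknown or untested is made for them only; others in the source may bear on it.

Three compounds share a core carrying a phenoxymethylbenzamide and a benzyl group on the ring nitrogen. Compound 1 `Cc1nn(Cc2cccc(C(N)=O)c2)c(C)c1NC(=O)c1ccc(COc2ccccc2)cc1` gives 9200 nM in a functional assay on MIA PaCa-2 cells (Homo sapiens) for antiproliferative activity, read by MTT assay, with a stated time of 72 h; on this read-out lower numbers stand for an effect already at smaller amounts and higher numbers for an effect only at larger amounts of compound. Compound 2 `Cc1nn(Cc2ccccc2C(N)=O)c(C)c1NC(=O)c1ccc(COc2ccccc2)cc1` gives 42000 nM in this assay, and the step of a 4.6-fold higher number from compound 1 to compound 2 (0.66 log units; beyond the scatter) stands beyond the scatter. Compound 3 `CNC(=O)c1cccc(Cn2nc(C)c(NC(=O)c3ccc(COc4ccccc4)cc3)c2C)c1` gives 6200 nM in this assay, the lowest number of the three, though its gap to compound 1, a 1.5-fold lower number from compound 1 to compound 3 (0.17 log units; within the scatter), lies within the scatter; against compound 2 the step of a 6.8-fold lower number from compound 2 to compound 3 (0.83 log units; beyond the scatter) is beyond it.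

Compound 4 `Cc1nn(Cc2cccc(C(=O)N(C)C)c2)c(C)c1NC(=O)c1ccc(COc2ccccc2)cc1` differs from compound 3 by methyl in place of hydrogen on an amide-type nitrogen, the amide-type nitrogen in question carrying a carbonyl carbon and a saturated chain carbon as its other neighbours. For the measured compounds named here, the one measured step of the same kind, a 1.5-fold lower number from compound 1 to compound 3 (0.17 log units; within the scatter), stayed within the scatter, so for compound 4 no step beyond the scatter is expected in this assay. The estimate for compound 4 is 6500 nM, between 2500 nM and 17000 nM, the expected step from compound 3 being a 1.0-fold higher number from compound 3 to compound 4 (0.02 log units; within the scatter).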

Compound 4, half-maximal effective concentration: 6400 nM
Compound 4: middle estimate off by 1.0-fold (0.01 log units), on the high side; measured number inside the range.
By their numbers in this assay, from the lowest: compounds 3, 4 and 1 (each within the scatter of the next); then compound 2.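

Replacing the last amide hydrogen with methyl on this amide-type nitrogen gives a step within the scatter in this assay (a 1.0-fold higher number from compound 3 to compound 4 (0.01 log units; within the scatter)). For the compounds shown here, with both hydrogens gone, dimethylamino in place of amino on the carbonyl carbon also stays within the scatter (a 1.4-fold lower number from compound 1 to compound 4 (0.16 log units; within the scatter)), so this position on the 3-carbamoylphenyl arm now holds its number without any amide hydrogen, where the earlier compounds covered the loss of only one. The gap to the 2-carbamoylphenyl arm persists with this fully substituted amide (a 6.6-fold lower number from compound 2 to compound 4 (0.82 log units; beyond the scatter)), which keeps the difference among these arms beyond the scatter.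

Still open, as far as these compounds go, is whether this flat response extends to a larger group on the nitrogen, such as a pyrrolidine amide or morpholine amide, or to a carboxylic acid in place of the amide. No measurement is at hand that accounts for the result.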